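Varying the Amide Tail on a Shared Core

The source may hold more compounds than are shown below. What is called first, only, known or untested is meant among the compounds shown, and "the series" means these compounds.

Compound 1 `O=C(NCCSc1nonc1/C(=N/O)Nc1ccc(F)c(C(F)F)c1)C1CS(=O)(=O)C1` gives 13 nM in an assay for inhibition of Indoleamine 2,3-dioxygenase 1 (Homo sapiens), read by fluorescence, with a stated time of 24 h; a lower number here means a stronger inhibitor, a higher number a weaker inhibitor.
Compound 2 `N#CCC(=O)NCCSc1nonc1/C(=N/O)Nc1ccc(F)c(C(F)F)c1` gives 6.5 nM in this assay.
Compound 3 `CC(C)(O)CC(=O)NCCSc1nonc1/C(=N/O)Nc1ccc(F)c(C(F)F)c1` gives 8.4 nM in this assay.

The three measured compounds share one core and differ only in the group on the carbonyl carbon of the amide. In this assay compound 3 holds the second highest of the three numbers; its nearest neighbour is compound 2, with a 1.3-fold higher number from compound 2 to compound 3 (0.11 log units; within the scatter), and its furthest is compound 1, with a 1.5-fold lower number from compound 1 to compound 3 (0.19 log units; within the scatter). Both steps sit within the usual scatter, so the three compounds cannot be ranked against one another.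

Compound 4 `CS(=O)(=O)CC(=O)NCCSc1nonc1/C(=N/O)Nc1ccc(F)c(C(F)F)c1` is the next member of this series. Its difference from compound 3 is methylsulfonyl in place of 1-hydroxy-1-methylethyl on a saturated chain carbon bound to a carbonyl carbon. The measured steps that bear on this change all replace the group on that same carbonyl carbon: a 2.0-fold lower number from compound 1 to compound 2 (0.30 log units; within the scatter), a 1.5-fold lower number from compound 1 to compound 3 (0.19 log units; within the scatter) and a 1.3-fold higher number from compound 2 to compound 3 (0.11 log units; within the scatter). None of them moves the number beyond the scatter, so the expected step of a 1.1-fold lower number from compound 3 to compound 4 (0.02 log units; within the scatter) is likewise small, with no clear direction. Compound 4 is therefore expected to give about 8 nM in this assay, with a likely range from 3.5 nM to 20 nM.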

Compound 4, half-maximal inhibitory concentration: 14 nM
For compound 4 the middle estimate is 1.8-fold (0.24 log units) below the measured one; the range from low to high includes it.
By their numbers in this assay, from the lowest: compounds 2, 3, 1 and 4 (each within the scatter of the next, the first and the last beyond it).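

Among these compounds, the step of a 2.2-fold higher number from compound 2 to compound 4 (0.33 log units; beyond the scatter) is the first to pass beyond the usual scatter, so the group on this saturated chain carbon can shift the number in this assay, though only modestly. Methylsulfonyl in place of 1-hydroxy-1-methylethyl gives a 1.7-fold higher number from compound 3 to compound 4 (0.22 log units; within the scatter) even though the hydrogen-bond donor of the leaving group is gone and the entering group has none, so at this position that count can change without a step that can be told from the scatter. The group of compound 1, which carries a ring, and the open-chain group of compound 4 are separated only by a 1.1-fold higher number from compound 1 to compound 4 (0.03 log units; within the scatter), so among these two compounds the ring makes no readable difference.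

No measurement shown here accounts for the size of any of these steps. Still open, on these data alone, is whether an amine, a carboxylic acid or a longer chain on the same carbonyl carbon would give a step beyond the scatter from compound 2, and whether any such group would do so towards a lower number rather than a higher one.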